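The compounds below may be only part of what the source reports. "The series", "measured", "known", "first", "only" and "open" are said of these compounds alone.

Measured compounds:

- compound 1, `N/C(=N\NC(=S)N1CCOCC1)c1ccccn1`: 87.2%
- compound 2, `N/C(=N\NC(=S)N1CCCC1)c1ccc(F)cn1`: 85.4%
- compound 3, `Cc1cccc(/C(N)=N/NC(=S)N2CCCC2)n1`: 80.1%

All three compounds share one core and were tested in a functional assay on HeLa cells (Homo sapiens) for cytotoxicity, read by MTT assay, with a stated time of 72 h, tested at 100 uM; a higher number here means more inhibition of growth at the concentration tested, a lower number less inhibition of growth. In this assay compound 1 gives 87.2%, compound 2 gives 85.4% and compound 3 gives 80.1%. Compound 3 carries the lowest of the three numbers, but its distance to compound 2 and to compound 1 both lie within the usual scatter of this kind of measurement, so the three values cannot be told apart with confidence.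

Compound 4, `N/C(=N\NC(=S)N1CCCC1)c1ccccn1`, has not yet been measured in this assay. It differs from compound 3 in one place: hydrogen in place of methyl on an aromatic carbon. Among the measured compounds shown here, no pair of measured compounds shows this exact change, so the expected step rests on how narrow the spread of the three known numbers is. Since compounds with different substitution on the ring and different saturated rings at the thiourea end all land in a similar band, the change from compound 3 to compound 4 is expected to give no step beyond the scatter, with a slight lean toward the values of compounds 1 and 2, that is a number 4.9 percentage points higher from compound 3 to compound 4 (within the scatter). Compound 4 is therefore estimated at 85%, within a range from 72% to 95%.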

Compound 4, percent growth inhibition at one concentration: 89.1%
Compound 4: the middle estimate sits 4.1 percentage points below what was measured; the measured number falls inside the stated range.
By their numbers in this assay, from the lowest: compounds 3, 2, 1 and 4 (each within the scatter of the next).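

Among the compounds shown here, with compound 4 in hand, the position next to the ring nitrogen can be read directly for the first time: in this assay, hydrogen in place of methyl on this aromatic carbon gives a number 9 percentage points higher from compound 3 to compound 4 (within the scatter), so within the scatter the two groups cannot be told apart here. Two other single changes behave alike, as loss of the fluoro group from an aromatic carbon gives a number 3.7 percentage points higher from compound 2 to compound 4 (within the scatter) and pyrrolidin-1-yl in place of morpholin-4-yl on a thiocarbonyl carbon gives a number 1.9 percentage points higher from compound 1 to compound 4 (within the scatter), both also within the scatter, so none of the three single changes separates its pair of compounds in this test of growth inhibition at one concentration. No supporting measurement is available to say what lies behind these small steps.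

Going by these compounds, it remains open whether an amine, a carboxylic acid or a longer alkyl chain on the aromatic carbon next to the ring nitrogen would stay in the same band. On these data alone, it is equally open whether a dimethylamino group on the thiocarbonyl carbon would do so, or whether these compounds would separate at lower concentrations.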